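Swapping methyl for chloro on a weak benzyl ether

The compounds below may be only part of what the source reports. "The series", "measured", "known", "first", "only" and "open" are said of these compounds alone.

Measured compounds in a functional assay on MDA-MB-231 cells (Homo sapiens) for cytotoxicity, read by MTT assay, with a stated time of 48 h; a higher number here means a weaker inhibitor, a lower number a stronger inhibitor:
compound 1 `Cc1cccc(Cn2cc(COc3ccc4c(=O)ccoc4c3)nn2)c1` gives 16000 nM
compound 2 `Cc1ccc(Cn2cc(COc3ccc4c(=O)ccoc4c3)nn2)cc1` gives only the assay limit of > 100000 nM

Compound 2 therefore stands at a limit rather than at a number: its value sits at the limit of > 100000 nM in this assay, at which 1 of the 2 values shown sits. Going by the values given here, the one measured step, an at least 6.2-fold higher number from compound 1 to compound 2 (0.79 log units; beyond the scatter), came from moving the methyl on the benzyl ring, so it is beyond the scatter but in a direction that ends in a limit. Compound 3 `O=c1ccoc2cc(OCc3cn(Cc4ccc(Cl)cc4)nn3)ccc12` differs from compound 2 by chloro in place of methyl on an aromatic carbon. Among the compounds with values here, no measured step swaps methyl for chloro, so the step from compound 1 to compound 2 bears on it only by showing that the 4-methylbenzyl starting point is already at the limit. For compound 3 the expected value is 60000 nM, with a range from 15000 nM to 200000 nM. Compound 3 is thus estimated to show a step of an at least 1.6-fold lower number from compound 2 to compound 3 (0.22 log units; that floor lies within the scatter), a direction that is only a guess.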

Compound 3, half-maximal inhibitory concentration: > 100000 nM
Compound 3: a limit, no number; the forecaster's own chance of this, stated with the estimate: 50%; at least 1.6-fold (0.22 log units) between middle value and limit.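

In this assay compound 3 gives > 100000 nM, which is a limit of the assay and not a number. Going by these compounds alone, measured against the only compound here with a number, the change to 4-chlorophenyl gives an at least 6.2-fold higher number from compound 1 to compound 3 (0.79 log units; beyond the scatter), so chloro, like methyl, ends at the limit when it sits para to a large group. The step for chloro in place of methyl itself cannot be read, as two limits give no size, and the count now stands thus: the limit of > 100000 nM in this assay, at which 2 of the 3 values shown sit.

From the compounds shown here alone, it remains open whether chloro at the place held by the methyl in compound 1 would give a number. Going by these compounds, it also remains open whether a different group para to a large group, such as a methoxy group or a carboxylic acid, would bring the value back within the range of the assay.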